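Solubilizing tail swap on the trifluoromethyl amide series

A few compounds are considered here, and "the series" means these few. Any claim that something is new, unique, unknown or untested is made for them only; others in the source may bear on it.

Measured compounds:
compound 1 `COc1cc2c(Oc3ccc(NC(=O)c4nn(-c5ccccc5C)c(=O)cc4C)cc3F)ccnc2cc1OCCCN1CCCC1` gives 1590 nM in a functional assay on NCI-H460 cells (Homo sapiens) for inhibition, read by MTT assay, with a stated time of 72 h; on this read-out lower numbers stand for stronger inhibition and higher numbers for weaker inhibition
compound 2 `COc1cc2c(Oc3ccc(NC(=O)c4nn(-c5ccccc5C(F)(F)F)c(=O)cc4C)cc3F)ccnc2cc1OCCCN1CCCC1` gives 210 nM in this assay

Compound 2 holds the lowest number of the two measured. Among the measured compounds shown here, the only measured step, a 7.6-fold lower number from compound 1 to compound 2 (0.88 log units; beyond the scatter), concerns the group on the aromatic ring attached to the core, not the chain end.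

Compound 3 `COc1cc2c(Oc3ccc(NC(=O)c4nn(-c5ccccc5C(F)(F)F)c(=O)cc4C)cc3F)ccnc2cc1OCCCN1CCN(C)CC1` differs from compound 2 in one place: 4-methylpiperazin-1-yl in place of pyrrolidin-1-yl on a saturated chain carbon, three bonds along the chain from an oxygen on an aromatic ring. For the measured compounds named here, both measured compounds carry the same pyrrolidin-1-yl chain end, so no measured step bears on this change. The number for compound 3 is therefore expected to sit close to that of compound 2, with no step beyond the scatter foreseen in this assay; the estimated step is a 1.2-fold higher number from compound 2 to compound 3 (0.08 log units; within the scatter). The estimate for compound 3 is 250 nM, within a range from 80 nM to 800 nM; the range is wide since nothing measured here speaks to the chain end.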

Compound 3, half-maximal inhibitory concentration: 240 nM
Estimate against measurement, compound 3: 1.0-fold (0.02 log units) above; the range from low to high includes it.
By their numbers in this assay, from the lowest: compounds 2 and 3 (each within the scatter of the next); then compound 1.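

Read in this assay this is the first step at the chain end, on a saturated chain carbon, three bonds along the chain from an oxygen on an aromatic ring: 4-methylpiperazin-1-yl in place of pyrrolidin-1-yl leaves the number within the scatter (a 1.1-fold higher number from compound 2 to compound 3 (0.06 log units; within the scatter)). On the trifluoromethyl compounds, a six-membered non-aromatic ring with 2 hetero atoms therefore stands at this chain end in place of a five-membered one with 1 hetero atom, with no step beyond the scatter, whereas trifluoromethyl in place of methyl on an aromatic carbon gave a step beyond it (a 7.6-fold lower number from compound 1 to compound 2 (0.88 log units; beyond the scatter)). Nothing at hand gives a reason for either outcome.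

Whether the chain end is as free on the methyl compound remains open, since 4-methylpiperazin-1-yl is shown only with trifluoromethyl on the aromatic ring. Also open, going by these compounds, is how far this tolerance extends, for example to a morpholin-4-yl or dimethylamino chain end, a carboxylic acid at the chain end, or a longer chain between the oxygen and the amine.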